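Swapping the Aromatic Ring for a Small Saturated Ring

This account rests on a few compounds, and the source may have more. Where it says the series, first, only, none or still open, it means among the compounds named here.

Compound 1 `CC1CN(C(=O)N2CC(c3nc(-c4cccc(Cl)c4)no3)C2)CC(C)O1`: 990 nM
Compound 2 `CC1CCCC(C(=O)N2CC(c3nc(-c4cccc(Cl)c4)no3)C2)C1`: > 10000 nM
Compound 3 `O=C(c1ccc(F)cc1)N1CC(c2nc(-c3cccc(Cl)c3)no2)C1`: 4000 nM

Three compounds share one core and differ only in the group attached to the carbonyl carbon. In an assay on HEK293 cells for negative allosteric modulation of metabotropic glutamate receptor 5 (Homo sapiens), read by FLIPR (on this read-out lower numbers stand for stronger inhibition and higher numbers for weaker inhibition), compound 1 gives 990 nM. Compound 2 reaches only a limit of this assay, > 10000 nM, so no number is known for it. Compound 3 gives 4000 nM in this assay, the higher of the two numbers, with a 4.0-fold higher number from compound 1 to compound 3 (0.61 log units; beyond the scatter) and an at least 2.5-fold lower number from compound 2 to compound 3 (0.39 log units; beyond the scatter).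

Compound 4 `O=C(C1CCC1)N1CC(c2nc(-c3cccc(Cl)c3)no2)C1` carries cyclobutyl in place of 4-fluorophenyl on a carbonyl carbon. For the measured compounds named here, the step that bears most on this change is the one from compound 2 to compound 3, where a saturated carbocycle gave way to the 4-fluorophenyl ring and the number fell, an at least 2.5-fold lower number from compound 2 to compound 3 (0.39 log units; beyond the scatter). Going back to a saturated ring, now smaller, points the other way: the number is expected to rise, with a fair chance that compound 4 is reported only at the limit, as compound 2 was the limit of > 10000 nM in this assay, at which 1 of the 3 values shown sits. The step from compound 3 to compound 4 is therefore estimated as a 2.0-fold higher number from compound 3 to compound 4 (0.30 log units; within the scatter). Compound 4 is expected to give about 8000 nM in this assay, in a range from 3000 nM to 20000 nM.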

Compound 4, half-maximal inhibitory concentration: 1500 nM
Compound 4: middle estimate off by 5.3-fold (0.73 log units), on the high side; the whole stated range lies above it.
By their numbers in this assay, from the lowest: compounds 1 and 4 (each within the scatter of the next); then compound 3. At a limit, above all of these: compound 2.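

This result shows that a saturated ring on the carbonyl carbon does not by itself raise the number, since cyclobutyl in place of 4-fluorophenyl gives a 2.7-fold lower number from compound 3 to compound 4 (0.43 log units; beyond the scatter) in this assay, the opposite of what the earlier step between a saturated carbocycle and the aromatic ring suggested. The two saturated carbocycles also differ clearly, with an at least 6.6-fold lower number from compound 2 to compound 4 (0.82 log units; beyond the scatter), so the identity of the ring matters and not only whether it is saturated, though this step rests on a limit of the assay and not on a number: the limit of > 10000 nM in this assay, at which 1 of the 4 values shown sits. Cyclobutyl and 2,6-dimethylmorpholin-4-yl cannot be told apart here, with a 1.5-fold higher number from compound 1 to compound 4 (0.18 log units; within the scatter), so a small all-carbon ring and this oxygen-containing ring serve equally well at this position.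

The compounds shown cannot separate ring size from the extra methyl group in compound 2, a question that cyclopentyl or unsubstituted cyclohexyl would address. As far as these compounds go, how cyclopropyl, an oxetane or an open chain such as isopropyl would fare on the same carbonyl carbon also remains open.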